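The source may report more compounds than this note shows. Statements on the series, on what has been measured and on what is new or still open speak of the compounds shown alone.

In a functional assay on the whole organism (strain Sprague-Dawley) for inhibition, with Rattus norvegicus as the target, with a stated time of 10 min (a lower number here means that less compound is needed, a higher number that more compound is needed for the effect), compound 1 (`Nc1ccccc1-c1ncc(C(=O)O)c(=O)[nH]1`) gives 50 mg/kg while compound 2 (`CCC(C)Oc1ccccc1-c1ncc(C(=O)O)c(=O)[nH]1`) gives 0.5 mg/kg as the lower of the two numbers. That places compound 2 lowest so far. Within the data shown here, the only measured step is a 100-fold lower number from compound 1 to compound 2 (2.00 log units; beyond the scatter) when sec-butoxy replaces amino on an aromatic carbon, and it is large and beyond the scatter. Compound 3 (`O=C(O)c1cnc(-c2ccccc2OCC2CC2)[nH]c1=O`) differs from compound 2 in one place: cyclopropylmethyl in place of sec-butyl on an oxygen on an aromatic ring with cyclopropylmethyl in place of sec-butyl on an oxygen on an aromatic ring. Among the measured compounds shown here, no measured step exchanges one group on that oxygen for another, so the large step gives no size for this change. A shift within the scatter is expected, with no direction favoured. The expected step is no change at the digits printed from compound 2 to compound 3 (within the scatter) in this assay as an estimate. For compound 3 the estimated dose is 0.5 mg/kg with an expected range of 0.15 mg/kg to 2 mg/kg in that same measurement.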

Compound 3, dose for 50% inhibition: 0.1 mg/kg
Estimate against measurement, compound 3: 5.0-fold (0.70 log units) above; measured number below the stated range.
By their numbers in this assay, from the lowest: compound 3; then compound 2; then compound 1.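

In this assay, among these compounds, the earlier compounds showed only that replacing amino with sec-butoxy changes the dose, whereas this result shows that the group on the oxygen also matters. Cyclopropylmethyl in place of sec-butyl, with the same count of heavy atoms but now with a three-membered ring, gives a 5.0-fold lower number from compound 2 to compound 3 (0.70 log units; beyond the scatter), and the comparison with the amino compound widens to a 500-fold lower number from compound 1 to compound 3 (2.70 log units; beyond the scatter). Nothing available explains why this exchange on the oxygen shifts the dose.

As far as these compounds go, what an isobutyl or cyclobutylmethyl group on that oxygen would give remains open, and with it whether the three-membered ring itself accounts for the step. Also open, from the compounds shown here alone, is whether the same exchange would have a similar effect with an amide in place of the carboxylic acid.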